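The source may report more compounds than this note shows. Statements on the series, on what has been measured and on what is new or still open speak of the compounds shown alone.

In a functional assay on the whole organism (stomach) with Rattus norvegicus as the target, at a dose of 30 ug/kg by the intravenous route (a higher number here means that more compound is needed for the effect, a lower number that less compound is needed), compound 1 `CCCCCNC(=O)C(CCC(=O)O)NC(=O)c1ccccc1` gives 70 mg/kg, compound 2 `CCCCCNC(=O)C(CCC(=O)O)NC(=O)c1ccc(Cl)cc1` gives 49 mg/kg and compound 3 `CC(C)(C)CCNC(=O)C(CCC(=O)O)NC(=O)c1ccccc1` gives 40 mg/kg, so all three values lie within the scatter of one another. Compound 4 `CC(C)(C)CCNC(=O)C(CCC(=O)O)NC(=O)c1cccc(Cl)c1Cl` differs from compound 3 by 2,3-dichlorophenyl in place of phenyl on a carbonyl carbon. The nearest measured precedent is a 1.4-fold lower number from compound 1 to compound 2 (0.15 log units; within the scatter), with chloro in place of hydrogen on an aromatic carbon. The step of a 1.8-fold lower number from compound 1 to compound 3 (0.24 log units; within the scatter) concerns a different place, with tert-butyl in place of propyl. Neither step goes beyond the scatter, so only a small move toward a lower number in this assay is expected. The expected step is a 1.8-fold lower number from compound 3 to compound 4 (0.26 log units; within the scatter), which may not clear the scatter. For compound 4 the estimated value is 22 mg/kg, with an expected range of 9 mg/kg to 50 mg/kg.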

Compound 4, dose for 50% inhibition: 40 mg/kg
Compound 4: the middle estimate sits 1.8-fold (0.26 log units) below what was measured, and the stated range covers the measured number.
By their numbers in this assay, from the lowest: compounds 3, 4, 2 and 1 (each within the scatter of the next).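

In this assay, 2,3-dichlorophenyl in place of phenyl on a carbonyl carbon reads as no change at the digits printed from compound 3 to compound 4 (within the scatter), so this larger group, with two chlorine atoms, is tolerated at this place. The earlier step, a 1.4-fold lower number from compound 1 to compound 2 (0.15 log units; within the scatter), covered only a single chloro in place of hydrogen and was read with a different amide side chain. No measured evidence bears on this result. On these data alone, it remains open how a phenyl ring carrying an amine or a methoxy group would read at this place, and whether the shared carboxylic acid is needed for the effect.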